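The compounds below may be only part of what the source reports. "The series", "measured", "known", "first", "only" and "open" are said of these compounds alone.

Compound 2 `CO[C@@H]1CC=C2N(c3ccc([N+](=O)[O-])cc3)C(=O)C[C@]2(c2ccccc2)O1` was examined in a functional assay on DU-145 cells (Homo sapiens) for cytotoxicity, read by sulforhodamine B assay, with a stated time of 48 h (on this read-out lower numbers stand for stronger inhibition and higher numbers for weaker inhibition), where compound 2 gives 8100 nM. Among the two compounds measured so far, compound 2 carries the highest number; its only companion is compound 1 `CO[C@@H]1CC=C2NN(c3ccccn3)C(=O)CC[C@]2(c2ccccc2)O1`, which is built on a different core and in this assay gives 1290 nM, a reading well beyond the scatter away from that of compound 2. Within the data shown here, no step between two measured compounds that differ in one place is available, so the change to compound 3 `CO[C@@H]1CC=C2N(c3cc(Cl)cc(Cl)c3)C(=O)C[C@]2(c2ccccc2)O1` rests on compound 2 alone. The change is 3,5-dichlorophenyl in place of 4-nitrophenyl on an amide-type nitrogen in a ring. Among the measured compounds shown here, with no comparable step to lean on, the step from compound 2 to compound 3 is expected to be small, estimated as a 1.4-fold lower number from compound 2 to compound 3 (0.13 log units; within the scatter), most likely within the scatter and without a clear direction. Compound 3 is therefore expected to give about 6000 nM in this assay, within a range from 1800 nM to 20000 nM.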

Compound 3, half-maximal inhibitory concentration: 8170 nM
Estimate against measurement, compound 3: 1.4-fold (0.13 log units) below; the range from low to high includes it.
By their numbers in this assay, from the lowest: compound 1; then compounds 2 and 3 (each within the scatter of the next).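

Among these compounds, the change to 3,5-dichlorophenyl in place of 4-nitrophenyl on the amide-type nitrogen in a ring gives a 1.0-fold higher number from compound 2 to compound 3 (0.00 log units; within the scatter) in this assay and provides the first reading of a single change at this position. At this place on the shared core, the two substituted phenyl groups cannot be told apart on this read-out, although the nitro group and the chlorine atoms are quite different substituents. Nothing measured here explains this result.

From the compounds shown here alone, two substituted phenyl groups are a narrow sample, so it remains open whether an unsubstituted phenyl, a phenyl bearing an amine or a carboxylic acid, or a benzyl group or longer alkyl chain would read differently at this nitrogen. Compound 1 differs from both in more than one place and so does not settle this.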